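The compounds below may be only part of what the source reports. "The series", "measured", "known", "first", "only" and "open" are said of these compounds alone.

In a functional assay on KYSE-450 cells (Homo sapiens) for inhibition, read by CCK-8 assay, with a stated time of 48 h (a higher number here means a weaker inhibitor, a lower number a stronger inhibitor), compound 1 (`COc1ccc(CN(C(=O)CSC(=S)N2CCN(C(C)=O)CC2)c2cc(OC)c(OC)c(OC)c2)cc1`) gives 370 nM and compound 2 (`COc1ccc(CN(C(=O)CSC(=S)N2CCc3ccccc32)c2cc(OC)c(OC)c(OC)c2)cc1`) gives 6940 nM as the higher of the two numbers, which marks it as the weaker inhibitor. Compound 3 (`COc1ccc(CN(C(=O)CSC(=S)N2CCCc3cc(C)ccc32)c2cc(OC)c(OC)c(OC)c2)cc1`) differs from compound 2 by 6-methyl-1,2,3,4-tetrahydroquinolin-1-yl in place of 2,3-dihydro-1H-indol-1-yl on a thiocarbonyl carbon with 6-methyl-1,2,3,4-tetrahydroquinolin-1-yl in place of 2,3-dihydro-1H-indol-1-yl on a thiocarbonyl carbon. Going by the values given here, the only measured step is a 19-fold higher number from compound 1 to compound 2 (1.27 log units; beyond the scatter) and it is large, but it removed 4-acetylpiperazin-1-yl, a different kind of swap, so no step beyond the scatter is expected in this assay here. The estimated step is a 1.4-fold lower number from compound 2 to compound 3 (0.14 log units; within the scatter) in size. Compound 3 is expected at 5000 nM with an estimated range from 1500 nM to 15000 nM.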

Compound 3, half-maximal inhibitory concentration: 5210 nM
Compound 3: the middle estimate sits 1.0-fold (0.02 log units) below what was measured; low and high end bracket the measured number.
By their numbers in this assay, from the lowest: compound 1; then compounds 3 and 2 (each within the scatter of the next).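

In this assay, putting 6-methyl-1,2,3,4-tetrahydroquinolin-1-yl in place of 2,3-dihydro-1H-indol-1-yl on the thiocarbonyl carbon gives a 1.3-fold lower number from compound 2 to compound 3 (0.12 log units; within the scatter), so a second fused-ring group, with a six-membered non-aromatic ring and a methyl, lands level with the first. The 4-acetylpiperazin-1-yl group stays well ahead of this group too, with a 14-fold higher number from compound 1 to compound 3 (1.15 log units; beyond the scatter). No measurement at hand explains either step.

Ring size and methyl changed together here, so their separate shares stay unknown. As far as these compounds go, it also remains open whether the advantage of compound 1 belongs to the acetyl group or its ring, which a plain piperazin-1-yl or morpholin-4-yl could help to tell.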